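This account rests on a few compounds, and the source may have more. Where it says the series, first, only, none or still open, it means among the compounds named here.

Measured in an ADME assay on HepG2 2.2.15 cells (Homo sapiens) for cytotoxicity; a lower number here means that less compound is tolerated, a higher number that more compound is tolerated:
compound 1 `CC(=O)N1CCC(C(=O)OCCc2c(-c3ccccc3Cl)c3cc(Cl)ccc3[nH]c2=O)CC1`: 82000 nM
compound 2 `O=C(OCCc1c(-c2ccccc2Cl)c2cc(Cl)ccc2[nH]c1=O)c1ccc([N+](=O)[O-])cc1`: 1600000 nM
compound 3 `O=C(/C=C/c1cccc(C(F)(F)F)c1)OCCc1c(-c2ccccc2Cl)c2cc(Cl)ccc2[nH]c1=O`: > 1400000 nM

Compound 3 stands at the limit of > 1400000 nM in this assay, at which 1 of the 3 values shown sits, so it has a limit and no exact number.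

Compound 4 `C/C=C(\C)C(=O)OCCc1c(-c2ccccc2Cl)c2cc(Cl)ccc2[nH]c1=O` carries 1-methylprop-1-en-1-yl in place of 2-(3-(trifluoromethyl)phenyl)ethenyl on a carbonyl carbon.

Two measured steps changed the group at this same place, and both were large: a 20-fold higher number from compound 1 to compound 2 (1.29 log units; beyond the scatter), and an at least 17-fold higher number from compound 1 to compound 3 (1.23 log units; beyond the scatter). Both started from the 1-acetylpiperidin-4-yl group of compound 1. The third comparison is a step that the limit leaves unreadable from compound 2 to compound 3. None of these steps tests a small group without a ring, so they offer only a loose guide. The group entering compound 4 has no ring, and it matches neither the group of compound 1 nor that of compound 3. A moderate move to a lower number is therefore expected, with wide uncertainty. The estimated change is an at least 2.3-fold lower number from compound 3 to compound 4 (0.36 log units; beyond the scatter). The expected value for compound 4 is 600000 nM, with an estimated range from 150000 nM to 1800000 nM.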

Compound 4, half-maximal cytotoxic concentration: 350000 nM
Compound 4: middle estimate off by 1.7-fold (0.23 log units), on the high side, and the stated range covers the measured number.
By their numbers in this assay, from the lowest: compound 1; then compound 4; then compound 2.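

In this assay, the 1-methylprop-1-en-1-yl group of compound 4 is the first group shown at this place without a ring, and it falls between two groups that carry one, with a 4.3-fold higher number from compound 1 to compound 4 (0.63 log units; beyond the scatter) and a 4.6-fold lower number from compound 2 to compound 4 (0.66 log units; beyond the scatter). Among these compounds, then, a ring in the group does not by itself set the number, and a much smaller group still gives an at least 4.0-fold lower number from compound 3 to compound 4 (0.60 log units; beyond the scatter). That step gives only a minimum size because compound 3 has a limit and no exact number: the limit of > 1400000 nM in this assay, at which 1 of the 4 values shown sits.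

The compounds shown leave open how a longer chain without a double bond, an amine or a carboxylic acid would behave on this carbonyl carbon. They also leave open whether the double bond of compound 4 matters, since no saturated chain of the same size appears beside it.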